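The compounds below may be only part of what the source reports. "The series", "measured", "known", "first", "only" and "open" are said of these compounds alone.

Measured so far:
Compound 1, `N=c1c(=O)[nH]nc2n1CCN2c1cccc(Cl)c1`: 36%
Compound 2, `N=c1c(=O)[nH]nc2n1CCN2c1ccccc1Cl`: 6%
Compound 3, `Cc1ccc(N2CCn3c2n[nH]c(=O)c3=N)cc1`: 37%

All three compounds share one core and differ only in the aromatic ring attached to it. In a functional assay on A549 cells (Homo sapiens) for antiproliferative activity, with a stated time of 72 h, tested at 10 ug/mL (a lower number here means a weaker effect, a higher number a stronger effect of the compound at the concentration tested), compound 3 gives 37% and compound 1 gives 36%; these two numbers lie within the usual scatter of each other and cannot be told apart. Compound 2, with 6%, gives a number that is clearly lower, beyond the scatter. So compound 3 stands at the upper end of the three numbers, with compound 1 next to it and compound 2 well below.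

Compound 4, `N=c1c(=O)[nH]nc2n1CCN2c1ccccc1`, is not yet measured. It differs from compound 3 in one place: hydrogen in place of methyl on an aromatic carbon. The methyl is removed and only a hydrogen remains at that aromatic carbon. Among the compounds with values here, no pair of measured compounds shows this exact change, so the size of the step has to be guessed. Removing a single carbon with no change in donors, acceptors or charge is a small change, and compound 1 shows that a different substituent pattern on this ring can still give a number close to that of compound 3. The step is estimated to be small, at most within the scatter: a number 7 percentage points lower from compound 3 to compound 4 (within the scatter). Compound 4 is therefore expected to give about 30% in this assay, with a range from 15% to 45%.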

Compound 4, a percentage reported as inhibition, at one concentration (the size of the read-out at that concentration, not a potency): 7%
Estimate against measurement, compound 4: 23 percentage points above, outside the stated range (below it).
By their numbers in this assay, from the lowest: compounds 2 and 4 (each within the scatter of the next); then compounds 1 and 3 (each within the scatter of the next).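

In this assay, putting hydrogen in place of methyl on this aromatic carbon, para to a large group, gives a number 30 percentage points lower from compound 3 to compound 4 (beyond the scatter), so a change of one carbon at this position can separate two compounds clearly, even though it adds or removes no hydrogen-bond donor, acceptor or charge. Hydrogen in place of chloro does not give a single outcome: it gives a number 29 percentage points lower from compound 1 to compound 4 (beyond the scatter), but also a number 1 percentage points higher from compound 2 to compound 4 (within the scatter), so among these compounds a substituent on the ring does not by itself go with the higher numbers, and compound 2 goes against any such pattern. No measurement shown here explains these differences.

From the compounds shown here alone, what stays open is whether the higher number at this position is tied to methyl or would also appear with another group, such as a methoxy group, an amine or a longer chain like ethyl. Going by these compounds, it is also open how a methyl group would behave on the two ring carbons that carry chloro in compound 1 and compound 2.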